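Series notes: chloro for fluoro, compound 3 to compound 4

The source may hold more compounds than are shown below. What is called first, only, known or untested is meant among the compounds shown, and "the series" means these compounds.

Compound 1 `COc1ccc2cc([C@H](C)c3nnc(SCc4ccccc4)n3-c3ccc(Cl)cc3)ccc2c1` gives 35800 nM in a functional assay on DU-145 cells (Homo sapiens) for cytotoxicity, read by MTT assay; on this read-out higher numbers stand for weaker inhibition and lower numbers for stronger inhibition. Within the data shown here, compound 2 `COc1ccc2cc([C@H](C)c3nnc(SCc4ccc(C)cc4)n3-c3ccc(Cl)cc3)ccc2c1` gives 18800 nM in this assay, and the one single-point step measured so far, a 1.9-fold lower number from compound 1 to compound 2 (0.28 log units; within the scatter), is a methyl in place of hydrogen on an aromatic carbon. Compound 3 `COc1ccc2cc([C@H](C)c3nnc(SCc4ccc(Cl)cc4)n3-c3ccc(F)cc3)ccc2c1` gives 57400 nM in this assay, the highest of the three numbers; its gap to compound 1 is within the scatter, while its gap to compound 2 is beyond it.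

Compound 4 `COc1ccc2cc([C@H](C)c3nnc(SCc4ccc(Cl)cc4)n3-c3ccc(Cl)cc3)ccc2c1` is not yet measured. It differs from compound 3 by chloro in place of fluoro on an aromatic carbon, which read one bond further out is 4-fluorophenyl to 4-chlorophenyl. Among the measured compounds shown here, no measured step among compound 1, compound 2 and compound 3 exchanges one halogen for another at this place; the step in hand, a 1.9-fold lower number from compound 1 to compound 2 (0.28 log units; within the scatter), concerns a different ring and a different group, and it stayed within the scatter. For the measured compounds named here, with no step of this kind to go on, the expectation for compound 4 in this assay is a step of a 1.3-fold lower number from compound 3 to compound 4 (0.11 log units; within the scatter), not beyond the scatter. Compound 4 is therefore estimated at 45000 nM, with a range from 20000 nM to 100000 nM.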

Compound 4, half-maximal inhibitory concentration: 109000 nM
The estimate for compound 4 lay 2.4-fold (0.38 log units) below the measured number, and the stated range ends below it.
By their numbers in this assay, from the lowest: compounds 2, 1, 3 and 4 (each within the scatter of the next, the first and the last beyond it).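

Among these compounds, exchanging the halogen on the 4-fluorophenyl group, the first such exchange, gives a 1.9-fold higher number from compound 3 to compound 4 (0.28 log units; within the scatter) in this assay and so does not separate fluoro from chloro at this place. The aromatic carbon at which compound 1, compound 2 and compound 4 differ now yields steps beyond the scatter, which methyl in place of hydrogen alone had not done: chloro in place of hydrogen gives a 3.0-fold higher number from compound 1 to compound 4 (0.48 log units; beyond the scatter) and chloro in place of methyl gives a 5.8-fold higher number from compound 2 to compound 4 (0.76 log units; beyond the scatter) and both are modest, so the read-out does respond to the group on that carbon. Nothing in hand speaks to what lies behind these steps.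

The compounds shown leave open whether the chloro steps at that carbon would hold with a 4-fluorophenyl group in place of the 4-chlorophenyl group, as compound 3 has no partner with hydrogen or methyl there. Also open, on these data alone, is how an amine or a carboxylic acid would read on that carbon, and how bromo or a plain hydrogen would read in place of the halogen on the other ring.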